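Aryl swap on the shared core: compound 3 to compound 4

This account rests on a few compounds, and the source may have more. Where it says the series, first, only, none or still open, it means among the compounds named here.

Measured so far in a functional assay on B16-F0 cells (Mus musculus) for inhibition, read by CCK-8 assay, with a stated time of 48 h; a lower number here means a stronger inhibitor, a higher number a weaker inhibitor:
- compound 1 `COc1ccc(-c2cc3nccc(-c4cc(OC)c(OC)c(OC)c4)n3n2)cc1[N+](=O)[O-]`: > 10000 nM, a limit of the assay
- compound 2 `Cc1ccc(-c2cc3nccc(-c4ccc(F)cc4)n3n2)cc1`: > 10000 nM, also a limit of the assay
- compound 3 `COc1cc(-c2ccnc3cc(-c4ccc5ccn(C)c5c4)nn23)cc(OC)c1OC`: 657 nM

Compound 3 holds the only number shown; the other two entries are limits, and both compound 1 and compound 2 sit at the limit of > 10000 nM in this assay, at which 2 of the 3 values shown sit. Within the data shown here, no pair of measured compounds differs in one place, so no measured step is available to calibrate the change.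

Compound 4 `COc1cc(-c2ccnc3cc(-c4cccc(C#N)c4)nn23)cc(OC)c1OC` differs from compound 3 by 3-cyanophenyl in place of 1-methyl-1H-indol-6-yl on an aromatic carbon. The shared core and the trimethoxyphenyl group are unchanged.

Without a measured step of this kind, the expectation rests on compound 3 alone. The step is expected to go toward weaker inhibition, a 3.0-fold higher number from compound 3 to compound 4 (0.48 log units; beyond the scatter), with wide uncertainty. Compound 4 is estimated at 2000 nM, in the range 500 nM to 10000 nM.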

Compound 4, half-maximal inhibitory concentration: > 10000 nM
Compound 4 was reported as a limit (the forecaster's own chance of this, stated with the estimate: 30%); at least 5.0-fold (0.69 log units) between middle value and limit.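

Swapping 1-methyl-1H-indol-6-yl for 3-cyanophenyl gives the first measured step at this position in this assay: an at least 15-fold higher number from compound 3 to compound 4 (1.18 log units; beyond the scatter). The shared core and the trimethoxyphenyl group, both present in compound 4, are therefore not enough to keep a measurable value in this pair. Compound 4 is only a limit, so the step has a lower bound but no exact size: the limit of > 10000 nM in this assay, at which 3 of the 4 values shown sit.

Going by these compounds, it remains open whether the step follows from losing the five-membered ring of the indole or from adding the nitrile. Plain phenyl and 1H-indol-6-yl at this position would help separate the two.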